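The source may hold more compounds than are shown below. What is called first, only, known or untested is meant among the compounds shown, and "the series" means these compounds.

Measured compounds:
compound 1 `COc1ccc(C2CC(c3ccccc3)=NN2C2=NC(=O)/C(=C3\C(=O)Nc4ccc(Br)cc43)S2)cc1` — 180 nM
compound 2 `CN(C)c1ccc(C2CC(c3ccccc3)=NN2C2=NC(=O)/C(=C3\C(=O)Nc4ccccc43)S2)cc1` — 1110 nM

Of the compounds shown here, two have been tested in a functional assay on cells (Cancer cell lines, Homo sapiens) for cytotoxicity, read by sulforhodamine B assay, with a stated time of 48 h; a lower number here means a stronger inhibitor of growth, a higher number a weaker inhibitor of growth. Compound 1 gives 180 nM. Compound 2 gives 1110 nM, the higher of the two numbers, and the gap between them lies beyond the usual scatter. Among the measured compounds shown here, these two compounds differ in two places at once, so their pair shows only that compound 2 is the weaker inhibitor of growth here, not which change is responsible.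

Compound 3 `CN(C)c1ccc(C2CC(c3ccccc3)=NN2C2=NC(=O)/C(=C3\C(=O)Nc4ccc(Br)cc43)S2)cc1` has not been measured. It differs from compound 2 by bromo in place of hydrogen on an aromatic carbon. For the measured compounds named here, no measured pair isolates this change. Going by the values given here, the only hint is that compound 1, which carries the bromo, gives the lower number, so a moderate drop in the number is expected, but a result within the scatter would not surprise. Compound 3 is therefore estimated at 600 nM, with a range from 250 nM to 1500 nM, a step of a 1.9-fold lower number from compound 2 to compound 3 (0.27 log units; within the scatter).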

Compound 3, concentration for 50% growth inhibition: 210 nM
For compound 3 the middle estimate is 2.9-fold (0.46 log units) above the measured one, and the stated range ends above it.
By their numbers in this assay, from the lowest: compounds 1 and 3 (each within the scatter of the next); then compound 2.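

In this assay, among the compounds shown here, bromo in place of hydrogen on this aromatic carbon of the fused two-ring system gives a 5.3-fold lower number from compound 2 to compound 3 (0.72 log units; beyond the scatter), the first step that isolates this single change and shows that it matters on its own. With the bromo in place, dimethylamino in place of methoxy gives a 1.2-fold higher number from compound 1 to compound 3 (0.07 log units; within the scatter), so this swap makes no clear difference here. No measurement at hand offers a reason for either step.

The compounds shown leave open whether chloro, fluoro or methyl on this same carbon would give a similar step. They also leave open whether bromo would give a step of the same size alongside methoxy, and whether a morpholine in place of dimethylamino would keep the number where it stands.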